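This account rests on a few compounds, and the source may have more. Where it says the series, first, only, none or still open, it means among the compounds named here.

Compound 1, `CC1(OC(=O)N2C[C@H]3COC[C@@H](C2)[C@@H]3Oc2ncnc(Nc3ccc(C#N)cc3Cl)c2F)CC1`, gives 10 nM in a functional assay on HEK293 cells for agonist activity at Glucose-dependent insulinotropic receptor (Homo sapiens), read by cAMP accumulation, with a stated time of 30 min; a lower number here means that less compound is needed, a higher number that more compound is needed for the effect.
Compound 2, `CC1(OC(=O)N2C[C@H]3COC[C@@H](C2)[C@@H]3Oc2ncnc(Nc3ccccc3F)c2F)CC1`, gives 6 nM in this assay.

Compound 2 holds the lowest of the two numbers, yet its gap to compound 1 lies within the scatter, so the two compounds are not distinguished here. Going by the values given here, the only measured step, a 1.7-fold lower number from compound 1 to compound 2 (0.22 log units; within the scatter), exchanges the whole aryl group on the nitrogen on the aromatic ring and leaves the read-out essentially unchanged.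

Compound 3, `CC1(OC(=O)N2C[C@H]3COC[C@@H](C2)[C@@H]3Oc2ncnc(Nc3c(F)cccc3F)c2F)CC1`, differs from compound 2 in one place: fluoro in place of hydrogen on an aromatic carbon. Among the compounds with values here, no measured pair shows this particular change, so the expectation for compound 3 rests on the single step from compound 1 to compound 2, which was within the scatter despite a larger alteration of the same ring. On that basis the fluoro addition is expected to move the number in this assay by no more than the scatter, in no settled direction, an expected step of no change at the digits printed from compound 2 to compound 3 (within the scatter). Compound 3 is therefore estimated at 6 nM, with a range from 2 nM to 18 nM.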

Compound 3, half-maximal effective concentration: 13 nM
The estimate for compound 3 lay 2.2-fold (0.34 log units) below the measured number; the measured number falls inside the stated range.
By their numbers in this assay, from the lowest: compounds 2, 1 and 3 (each within the scatter of the next, the first and the last beyond it).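

In this assay, going by these compounds alone, fluoro in place of hydrogen on the aromatic carbon turns 2-fluorophenyl into 2,6-difluorophenyl and gives a 2.2-fold higher number from compound 2 to compound 3 (0.34 log units; beyond the scatter), so this single-atom change produces the only step in the set that lies beyond the scatter, though a modest one, whereas the earlier exchange of the whole aryl group did not. The comparison with the other aryl group is less clear-cut: 2,6-difluorophenyl in place of 2-chloro-4-cyanophenyl gives a 1.3-fold higher number from compound 1 to compound 3 (0.11 log units; within the scatter), so these two aryl groups are not distinguished here, and the position ortho to a large group is shown to matter only on the 2-fluorophenyl ring. The compounds shown offer no measurement that explains the step.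

On these data alone, it remains open whether the step belongs to fluoro alone or would recur with a chloro, methyl, methoxy or amino group on the same aromatic carbon. As far as these compounds go, it is also open how the plain phenyl group, with no fluoro at all, would stand against compound 2 and compound 3, and whether adding fluoro to other aryl groups would give a step of similar size.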